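A few compounds are considered here, and "the series" means these few. Any claim that something is new, unique, unknown or untested is made for them only; others in the source may bear on it.

Measured so far in a physicochemical assay for lipophilicity, read by HPLC; on this read-out higher numbers stand for higher lipophilicity and lower numbers for lower lipophilicity:
compound 1 `Cn1cc(-c2ncc(C#N)c(N3C[C@@H]4C[C@H]3CN4CC3CC3)n2)cn1` — 1.5
compound 2 `C[C@@H]1C[C@H]1C(=O)N1CCN(c2cnc(C#N)c(-c3cnn(C)c3)n2)C[C@H]1C` — 1.6
compound 3 `Cn1cc(-c2ncc(C#N)c(N3C[C@@H]4C[C@H]3CN4c3cccc(F)c3)n2)cn1` — 3.1

Compound 2 stands second highest of the three in this assay; its value sits within the scatter of compound 1 and well beyond the scatter of compound 3. Among the measured compounds shown here, the only step measured, a number 1.60 log units higher from compound 1 to compound 3 (beyond the scatter), is large, but it concerns a different change on a different compound pair.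

Compound 4 `C[C@@H]1CN(c2cnc(C#N)c(-c3cnn(C)c3)n2)CCN1C(=O)C1CC1` has not yet been measured. Its difference from compound 2: hydrogen in place of methyl on a saturated ring carbon. For the measured compounds named here, no measured step in this assay bears directly on the loss of a methyl from a saturated ring carbon, so the expectation rests on the small size of the change alone.

A small downward step, probably within the scatter, is expected: a number 0.30 log units lower from compound 2 to compound 4 (within the scatter). Compound 4 is therefore estimated at 1.3, with a range from 0.9 to 1.7.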

Compound 4, distribution coefficient: 1.8
Estimate against measurement, compound 4: 0.50 log units below, outside the stated range (above it).
By their numbers in this assay, from the lowest: compounds 1, 2 and 4 (each within the scatter of the next); then compound 3.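

In this assay the change from 2-methylcyclopropyl to cyclopropyl gives a number 0.20 log units higher from compound 2 to compound 4 (within the scatter) and so does not separate the two compounds. Among the compounds shown here, this is the only reading at this place on the three-membered ring, and in this pair the loss of methyl, one heavy atom, carries no step beyond the scatter. No measured evidence accounts for the result.

Open, from the compounds shown here alone, is whether an amine, a carboxylic acid or a longer chain on this saturated ring carbon would give a step beyond the scatter. One pair also cannot show whether the methyl step holds on other compounds.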